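This account rests on a few compounds, and the source may have more. Where it says the series, first, only, none or still open, it means among the compounds named here.

Measured compounds:

Compound 1 `N=C(N)N/N=C/c1c(-c2cccs2)nc2sccn12` gives 24500 nM in a functional assay on cells (Cancer cell lines, Homo sapiens) for inhibition; a lower number here means a stronger inhibitor of growth, a higher number a weaker inhibitor of growth.
Compound 2 `N=C(N)N/N=C/c1c(-c2ccsc2)nc2sccn12` gives 28800 nM in this assay.
Compound 3 `Cc1cn2c(/C=N/Nc3ccccn3)c(-c3ccc(Cl)c([N+](=O)[O-])c3)nc2s1` gives 38900 nM in this assay.

Among these three, compound 1 carries the lowest number, yet its nearest neighbour, compound 2, sits only a 1.2-fold higher number from compound 1 to compound 2 (0.07 log units; within the scatter) away, and compound 3 lies no further than the scatter of this assay allows, so none of the three can be called stronger or weaker than another. The unmeasured compound 4 `Cc1cn2c(/C=N/NC(=N)N)c(-c3cccs3)nc2s1` shares the core of compound 1 and differs from it in one place: methyl in place of hydrogen on an aromatic carbon. Going by the values given here, the only measured step, from compound 1 to compound 2, concerns an exchange of one thiophene isomer for another on the core and says nothing about a methyl added to the core itself. Compound 3 does carry such a methyl, but it differs from compound 1 in several other places at once, so its value alone cannot be read as the effect of the methyl. Among the compounds with values here, with no step that bears on this change, the expectation for compound 4 is a step of about a 1.0-fold higher number from compound 1 to compound 4 (0.01 log units; within the scatter), that is, none beyond the scatter. Compound 4 is therefore estimated at 25000 nM, within a range from 10000 nM to 60000 nM.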

Compound 4, concentration for total growth inhibition: 12300 nM
Compound 4: middle estimate off by 2.0-fold (0.31 log units), on the high side; the range from low to high includes it.
By their numbers in this assay, from the lowest: compounds 4, 1, 2 and 3 (each within the scatter of the next, the first and the last beyond it).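

Placing methyl in place of hydrogen on an aromatic carbon next to the ring sulfur gives a 2.0-fold lower number from compound 1 to compound 4 (0.30 log units; within the scatter) in this assay, so this position of the shared core can carry a methyl with no loss of growth inhibition. Going by these compounds alone, this is the first one-place step that touches the core itself, whereas the earlier step, a 1.2-fold higher number from compound 1 to compound 2 (0.07 log units; within the scatter), exchanged only one thiophene isomer for the other. Although this step lies at the edge of what repeated measurements could separate, the compounds offer no independent measurement that could explain it.

The compounds shown leave open whether a longer chain such as ethyl, or a group such as an amine or a carboxylic acid, would be accepted at this position. They also leave open whether the methyl would give a similar step on compound 2, which carries thiophen-3-yl.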